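The source may hold more compounds than are shown below. What is called first, only, known or untested is meant among the compounds shown, and "the series" means these compounds.

In a functional assay on MDA-MB-436 cells (Homo sapiens) for antiproliferative activity, read by MTT assay, with a stated time of 48 h (a lower number here means a stronger inhibitor, a higher number a weaker inhibitor), three compounds that share one core have been measured so far. Compound 1 `CCS(=O)(=O)N1CCN(c2ncnc3sc(-c4ccc(N5CCN(C)CC5)cc4)cc23)CC1`, with ethylsulfonyl on an amine nitrogen in a ring, gives 10600 nM. Compound 2 `CN1CCN(c2ccc(-c3cc4c(N5CCN(S(=O)(=O)C6CC6)CC5)ncnc4s3)cc2)CC1`, with cyclopropyl in place of ethyl on the sulfonyl sulfur, gives 10600 nM, which is no change at the digits printed from compound 1 to compound 2 (within the scatter). Compound 3 `CN1CCN(c2ccc(-c3cc4c(N5CCN(C(=O)Nc6ccccc6)CC5)ncnc4s3)cc2)CC1` carries phenylcarbamoyl on that same nitrogen and gives 7090 nM. Its two measured steps are a 1.5-fold lower number from compound 1 to compound 3 (0.17 log units; within the scatter) and a 1.5-fold lower number from compound 2 to compound 3 (0.17 log units; within the scatter), so compound 3 cannot be told apart from the other two on these numbers.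

Compound 4 `CN1CCN(c2ccc(-c3cc4c(N5CCN(C(=O)Nc6ccc(Cl)cc6)CC5)ncnc4s3)cc2)CC1` differs from compound 3 in one place: chloro in place of hydrogen on an aromatic carbon. In other words, phenyl becomes 4-chlorophenyl. Within the data shown here, no measured compound carries a chloro group, so the data do not test this change directly. Among the measured compounds shown here, the only guide is the size of the steps so far. Exchanging the whole group on the nitrogen gave a 1.5-fold lower number from compound 1 to compound 3 (0.17 log units; within the scatter), and that stayed within the scatter. A step beyond the scatter is therefore not expected here, and the expected step is a 1.2-fold lower number from compound 3 to compound 4 (0.07 log units; within the scatter). For compound 4 the estimated value is 6000 nM, with an expected range from 2500 nM to 12000 nM.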

Compound 4, half-maximal inhibitory concentration: 9270 nM
For compound 4 the middle estimate is 1.5-fold (0.19 log units) below the measured one, within the range that was stated.
By their numbers in this assay, from the lowest: compounds 3, 4, 1 and 2 (each within the scatter of the next).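

Among these compounds, compound 4 gives the first reading of a group on the aromatic ring of the phenylcarbamoyl unit: in this assay, going from phenyl to 4-chlorophenyl is a 1.3-fold higher number from compound 3 to compound 4 (0.12 log units; within the scatter), so adding this single chlorine atom on an aromatic carbon, para to a large group, produces no step that can be told apart from the scatter. The (4-chlorophenyl)carbamoyl group also cannot be separated from either sulfonyl group on the ring nitrogen, with a 1.1-fold lower number from compound 2 to compound 4 (0.06 log units; within the scatter) and a 1.1-fold lower number from compound 1 to compound 4 (0.06 log units; within the scatter), so this fuller group on that nitrogen shows no difference from the smaller ones in this assay. No accompanying measurement speaks to what lies behind these numbers.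

As far as these compounds go, it remains open whether another group on that same aromatic carbon, such as an amine or a carboxylic acid, would produce a step beyond the scatter. Also open, from the compounds shown here alone, is whether a longer chain in place of the phenyl ring on the carbamoyl nitrogen would move the number at all.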